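Swapping a Naphthyl Sulfonyl Group for 2-Nitrophenyl

The compounds below may be only part of what the source reports. "The series", "measured", "known", "first", "only" and "open" are said of these compounds alone.

- Compound 1 `O=C(/C=C/c1cn(S(=O)(=O)c2ccc([N+](=O)[O-])cc2)c2ccccc12)c1ccncc1`: 18300 nM
- Compound 2 `O=C(/C=C/c1cn(S(=O)(=O)c2cccc([N+](=O)[O-])c2)c2ccccc12)c1ccncc1`: 42600 nM
- Compound 3 `O=C(/C=C/c1cn(S(=O)(=O)c2cccc3ccccc23)c2ccccc12)c1ccncc1`: 62900 nM

In a functional assay on HepG2 cells (Homo sapiens) for antiproliferative activity, read by MTT assay, with a stated time of 48 h (on this read-out lower numbers stand for stronger inhibition and higher numbers for weaker inhibition), compound 3 gives 62900 nM and shares the upper end of the set with compound 2. The data show a 1.5-fold higher number from compound 2 to compound 3 (0.17 log units; within the scatter), and also a 3.4-fold higher number from compound 1 to compound 3 (0.54 log units; beyond the scatter). Compound 4 `O=C(/C=C/c1cn(S(=O)(=O)c2ccccc2[N+](=O)[O-])c2ccccc12)c1ccncc1` carries 2-nitrophenyl in place of naphthalen-1-yl on a sulfonyl sulfur. The two steps above bear on this change when read in reverse, and a 2.3-fold higher number from compound 1 to compound 2 (0.37 log units; beyond the scatter) shows that the two measured nitrophenyl compounds differ from each other. A small move towards a lower number is therefore expected, and the estimate is a 2.1-fold lower number from compound 3 to compound 4 (0.32 log units; beyond the scatter). For compound 4 the expected value is 30000 nM, with an estimated range of 13000 nM to 70000 nM.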

Compound 4, half-maximal inhibitory concentration: 31700 nM
For compound 4 the middle estimate is 1.1-fold (0.02 log units) below the measured one, and the stated range covers the measured number.
By their numbers in this assay, from the lowest: compounds 1, 4, 2 and 3 (each within the scatter of the next, the first and the last beyond it).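

In this assay 2-nitrophenyl on a sulfonyl sulfur does not separate from any of the groups measured earlier at this place: naphthalen-1-yl (a 2.0-fold lower number from compound 3 to compound 4 (0.30 log units; within the scatter)), 3-nitrophenyl (a 1.3-fold lower number from compound 2 to compound 4 (0.13 log units; within the scatter)) or 4-nitrophenyl (a 1.7-fold higher number from compound 1 to compound 4 (0.24 log units; within the scatter)). Compound 4 thus lies within the scatter of all three, even though compound 1 and compound 3 are separated beyond it (a 3.4-fold higher number from compound 1 to compound 3 (0.54 log units; beyond the scatter)). No measurement given here accounts for these numbers. The compounds shown leave open whether an aminophenyl group or a longer alkyl chain on the sulfonyl sulfur would give a number outside the span of these four.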